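A few compounds are considered here, and "the series" means these few. Any claim that something is new, unique, unknown or untested is made for them only; others in the source may bear on it.

In this assay an assay on isolated protein for inhibition of Polyunsaturated fatty acid lipoxygenase ALOX15 (Homo sapiens), read by spectrophotometry (a higher number here means a weaker inhibitor, a lower number a stronger inhibitor), compound 1, `Oc1ccc(Cl)cc1-c1cc(-c2ccccc2Cl)[nH]n1`, gives no number at all but only the limit of the measurement, > 50000 nM. Compound 2, `Cc1ccc(O)c(-c2cc(C(=O)NCc3ccccc3)[nH]n2)c1`, also stops at the limit, > 50000 nM. Within the data shown here, compound 3, `Cc1ccccc1-c1cc(-c2ccccc2O)[nH]n1`, is the one compound of the three that yields a number, 7000 nM. Two of the three values therefore sit at the same boundary, (the limit of > 50000 nM in this assay, at which 2 of the 3 values shown sit), and compound 1 is one of them: on the numbers shown it stands not as a measured inhibitor but as a compound for which the test reached its limit before any inhibition could be quantified.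

Compound 4, `Oc1ccc(Br)cc1-c1cc(-c2ccccc2Cl)[nH]n1`, has not yet been measured in this assay. It differs from compound 1 in a single place: bromo in place of chloro on an aromatic carbon. Bromo and chloro are close relatives among the halogens, and with compound 1 already at the limit there is no measured step between a chloro and a bromo analogue here to lean on.

The expectation is for no step beyond the usual scatter, and in this assay compound 4 is estimated at 70000 nM, within a range from 25000 nM to 200000 nM. The expected shift a step that the limit leaves unreadable from compound 1 to compound 4 is essentially nil, with a good chance that the assay again reports only a limit.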

Compound 4, half-maximal inhibitory concentration: > 50000 nM
Compound 4 was reported as a limit; the forecaster's own chance of this, stated with the estimate: 70%; the middle value does not contradict the limit.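

In this assay compound 4 gives > 50000 nM, which is a limit and not a number. Compound 1 is also reported only as a limit, so no step between compound 1 and compound 4 can be read: the limit of > 50000 nM in this assay, at which 3 of the 4 values shown sit.

The compounds shown leave open whether bromo in place of chloro changes inhibition at all.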